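This account rests on a few compounds, and the source may have more. Where it says the series, first, only, none or still open, it means among the compounds named here.

Working notes on the series. Compound 1 `O=C(O)CN1Cc2ccc(NC(=O)c3ccc(C4CCNCC4)cc3)cc2C1=O` carries a carboxymethyl group on the amide-type nitrogen of the shared core; in a functional assay on a cell-free system (Platelet, plasma, Homo sapiens) for inhibition (on this read-out lower numbers stand for stronger inhibition and higher numbers for weaker inhibition), compound 1 gives 24000 nM. Compound 2 `O=C(O)CCCN1Cc2ccc(NC(=O)c3ccc(C4CCNCC4)cc3)cc2C1=O`, with 3-carboxypropyl at that nitrogen, gives 410000 nM, and compound 3 `CC(CC(=O)O)N1Cc2ccc(NC(=O)c3ccc(C4CCNCC4)cc3)cc2C1=O`, with 1-(carboxymethyl)ethyl there, gives 6200 nM. Among the three measured numbers compound 1 stands second highest, a 3.9-fold lower number from compound 1 to compound 3 (0.59 log units; beyond the scatter) separating it from the nearest and a 17-fold higher number from compound 1 to compound 2 (1.23 log units; beyond the scatter) from the furthest. The remaining measured step, a 66-fold lower number from compound 2 to compound 3 (1.82 log units; beyond the scatter), also concerns only the acid-bearing chain.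

Compound 4 `O=C(O)CN1Cc2ccc(NC(=O)c3ccc(N4CCNCC4)cc3)cc2C1=O` keeps the carboxymethyl chain of compound 1 and differs at the other end of the molecule. The change is piperazin-1-yl in place of piperidin-4-yl on an aromatic carbon. None of the three measured steps touches that position; all vary the chain on the amide-type nitrogen, so they give no direct guide to the size or direction of this change. The expectation in this assay is therefore a step of no change at the digits printed from compound 1 to compound 4 (within the scatter) estimated to fall within the usual scatter, with the range kept wide for lack of any precedent in the set. Compound 4 is expected to give about 24000 nM in this assay, within 7000 nM to 80000 nM.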

Compound 4, half-maximal inhibitory concentration: 3300 nM
Compound 4: the middle estimate sits 7.3-fold (0.86 log units) above what was measured, outside the stated range (below it).
By their numbers in this assay, from the lowest: compounds 4 and 3 (each within the scatter of the next); then compound 1; then compound 2.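

The aromatic carbon para to a large group, which carries piperidin-4-yl in compounds 1 to 3, responds to change in this assay: piperazin-1-yl in place of piperidin-4-yl gives a 7.3-fold lower number from compound 1 to compound 4 (0.86 log units; beyond the scatter), so the number moves at this end of the molecule as well as at the acid-bearing chain. The exchange keeps the heavy-atom count and the six-membered non-aromatic ring, with a ring nitrogen in the place of a ring carbon, so a swap of this small extent is enough for a modest step beyond the scatter on the carboxymethyl chain. Nothing at hand accounts for the step.

Going by these compounds, the step rests on the carboxymethyl chain alone, so it remains open whether piperazin-1-yl shifts the number by a similar size on the 3-carboxypropyl chain of compound 2 or the 1-(carboxymethyl)ethyl chain of compound 3. Also open, on these data alone, is how a morpholin-4-yl ring, a 4-methylpiperazin-1-yl ring or an open-chain amine on the same aromatic carbon would compare with piperazin-1-yl.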